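Chloro on the phenyl ring of compound 3

The compounds below may be only part of what the source reports. "The series", "measured", "known", "first", "only" and "open" are said of these compounds alone.

In a functional assay on PC-3 cells (Homo sapiens) for inhibition, with a stated time of 48 h (on this read-out higher numbers stand for weaker inhibition of growth and lower numbers for stronger inhibition of growth), compound 1 `COc1ccccc1/C=C/C(=O)c1c(O)cc2occc2c1OC` gives > 100000 nM as a limit and not a number. Compound 3 `C=CCc1c(O)c(C(=O)/C=C/c2ccccc2)c(OC)c2ccoc12` gives 3680 nM and compound 2 `COc1c(C(=O)/C=C/c2ccc(Cl)cc2)c(O)c(Br)c2occc12` gives 2940 nM in this assay, and these two numbers lie within the usual scatter of each other. Compound 3 therefore stands level with compound 2 on the numbers available.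

Compound 4 `C=CCc1c(O)c(C(=O)/C=C/c2ccc(Cl)cc2)c(OC)c2ccoc12` differs from compound 3 in a single place chloro in place of hydrogen on an aromatic carbon, para to a large group, which turns phenyl to 4-chlorophenyl. Going by the values given here, no measured pair isolates this change, so the expectation rests on little. Among the compounds with values here, the only measured compound with a 4-chlorophenyl group is compound 2 at 2940 nM in this assay, and it also differs from compound 4 elsewhere on the shared core. With that single value as a guide, no step beyond the scatter is expected in this assay, in either direction. The estimated step of a 1.2-fold lower number from compound 3 to compound 4 (0.06 log units; within the scatter) is accordingly small. For compound 4 the expected value is 3200 nM, with an estimated range from 1300 nM to 8000 nM.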

Compound 4, concentration for 50% growth inhibition: 3810 nM
Estimate against measurement, compound 4: 1.2-fold (0.08 log units) below; measured number inside the range.
By their numbers in this assay, from the lowest: compounds 2, 3 and 4 (each within the scatter of the next). At a limit, above all of these: compound 1.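

In this assay, the pair that isolates chloro in place of hydrogen on an aromatic carbon, para to a large group, reads a 1.0-fold higher number from compound 3 to compound 4 (0.02 log units; within the scatter), so phenyl to 4-chlorophenyl gives no step beyond the scatter on this background. With the 4-chlorophenyl group common to both compounds, allyl in place of bromo on an aromatic carbon reads a 1.3-fold higher number from compound 2 to compound 4 (0.11 log units; within the scatter), which also stays within the scatter and leaves compound 2, compound 3 and compound 4 level in this assay. No measured property among the data bears on these two results.

From the compounds shown here alone, whether an amine or a carboxylic acid in place of the chloro, or a longer chain in place of the allyl, would give a step beyond the scatter remains open. Compound 1 gives > 100000 nM, which is a limit and not a number, and it differs from the other compounds in more than one place, so no single change can be tied to its read-out.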